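Compound 3 to compound 4: a piperazine swap

The source may hold more compounds than are shown below. What is called first, only, known or untested is meant among the compounds shown, and "the series" means these compounds.

Values in a functional assay on SK-MEL-28 cells (Homo sapiens) for cytotoxicity, read by MTT assay, with a stated time of 3 days; a lower number here means a stronger inhibitor, a higher number a weaker inhibitor:
- Compound 1 `N#Cc1c(Nc2ccccc2)nc(SCc2nc3ccccc3[nH]2)nc1-c1ccccc1`: 8.9 nM
- Compound 2 `CNc1nc(SCc2nc3ccccc3[nH]2)nc(-c2ccccc2)c1C#N`: 2.87 nM
- Compound 3 `N#Cc1c(Nc2ccccn2)nc(SCc2nc3ccccc3[nH]2)nc1-c1ccccc1`: 8.9 nM

Compound 3 stands level with compound 1 at the digits shown, and no change at the digits printed from compound 1 to compound 3 (within the scatter). Compound 2 is the only one apart from the other two, with a 3.1-fold higher number from compound 2 to compound 3 (0.49 log units; beyond the scatter).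

The next compound is compound 4 `CN1CCN(c2nc(SCc3nc4ccccc4[nH]3)nc(-c3ccccc3)c2C#N)CC1`, in which 4-methylpiperazin-1-yl stands in place of (pyridin-2-yl)amino on an aromatic carbon: 4-methylpiperazin-1-yl in place of (pyridin-2-yl)amino on an aromatic carbon.

The measured steps all change the group on a nitrogen at this same place. Replacing phenyl with pyridin-2-yl gives no change at the digits printed from compound 1 to compound 3 (within the scatter), while replacing phenyl with methyl gives a 3.1-fold lower number from compound 1 to compound 2 (0.49 log units; beyond the scatter). Among the compounds with values here, these steps are modest at most, but they are only a partial guide, since no measured compound carries a non-aromatic ring at this place. Within the data shown here, the data therefore offer no direct precedent for the swap.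

In this assay, no step beyond the scatter is expected, and the range is kept wide in both directions. The expected step is a 1.3-fold lower number from compound 3 to compound 4 (0.10 log units; within the scatter). For compound 4, the estimated value is 7 nM, with an expected range from 2.5 nM to 25 nM.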

Compound 4, half-maximal inhibitory concentration: 20 nM
Beside the measured number, compound 4's estimate is 2.9-fold (0.46 log units) below it, within the range that was stated.
By their numbers in this assay, from the lowest: compound 2; then compounds 1 and 3 (each within the scatter of the next); then compound 4.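

In this assay, compound 4 has the highest number of the four compounds, and each of its steps lies beyond the scatter: (a 2.2-fold higher number from compound 3 to compound 4 (0.35 log units; beyond the scatter)), (a 2.2-fold higher number from compound 1 to compound 4 (0.35 log units; beyond the scatter)) and (a 7.0-fold higher number from compound 2 to compound 4 (0.84 log units; beyond the scatter)). This position therefore responds to more than the group on an exocyclic nitrogen: (pyridin-2-yl)amino and 4-methylpiperazin-1-yl have the same heavy-atom count and the same hydrogen-bond acceptor count, yet the swap moves the number beyond the scatter, whereas the earlier change from phenyl to pyridin-2-yl on the nitrogen did not. Compound 4 is also the only one of the four with a non-aromatic ring here and with no hydrogen-bond donor in this group, but no evidence on hand explains the rise.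

On these data alone, the two structural changes are joined in compound 4, so their separate contributions remain open. Cyclohexylamino would keep the hydrogen on the nitrogen with a non-aromatic ring, while dimethylamino would remove that hydrogen without a ring, and morpholin-4-yl would test the distal nitrogen of the piperazine.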